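The source may hold more compounds than are shown below. What is called first, only, known or untested is meant among the compounds shown, and "the series" means these compounds.

Measured compounds and their values in a physicochemical assay for lipophilicity, read by HPLC, in phosphate buffer, measured as chromatographic lipophilicity, at pH 7.4; on this read-out lower numbers stand for lower lipophilicity and higher numbers for higher lipophilicity:

compound 1, `COc1ccc2nc(C)cc(OCC(=O)Nc3c(C)cccc3C)c2c1`, gives 4.55.
compound 2, `COc1ccc2nc(C)cc(OCC(=O)Nc3cc(C)c(F)c(C)c3)c2c1`, gives 5.5.
compound 3, `COc1ccc2nc(C)cc(OCC(=O)Nc3noc(C)c3C)c2c1`, gives 3.3.

Compound 3 stands lowest of the three in this assay, clearly separated from both others. Compound 4, `COc1ccc2nc(C)cc(OCC(=O)NNC(=O)c3ccncc3)c2c1`, differs from it in one place: ((pyridin-4-yl)carbonyl)amino in place of 4,5-dimethyl-1,2-oxazol-3-yl on an amide-type nitrogen. Among the compounds with values here, no measured step covers this exact exchange. The steps that come closest are those leading into compound 3: a number 1.25 log units lower from compound 1 to compound 3 (beyond the scatter) and a number 2.20 log units lower from compound 2 to compound 3 (beyond the scatter), both large and both downward when a group carrying two dimethyl-substituted carbons on a benzene ring gave way to the five-membered ring with two hetero atoms. The entering group in compound 4 again carries a ring with a hetero atom and adds a hydrogen-bond donor, so a further step downward, of moderate size, is the expectation here, expressed as a number 1.00 log units lower from compound 3 to compound 4 (beyond the scatter). Compound 4 is therefore estimated at 2.3 in this assay, within a range from 1.5 to 3.1.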

Compound 4, distribution coefficient: 1.48
Compound 4: middle estimate off by 0.82 log units, on the high side, outside the stated range (below it).
By their numbers in this assay, from the lowest: compound 4; then compound 3; then compound 1; then compound 2.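

Compound 4 sets a new low end for the group on the amide-type nitrogen in this assay: ((pyridin-4-yl)carbonyl)amino gives a number 1.82 log units lower from compound 3 to compound 4 (beyond the scatter) when it replaces the 4,5-dimethyl-1,2-oxazol-3-yl group. Against the two phenyl groups the drop is wider still, at a number 3.07 log units lower from compound 1 to compound 4 (beyond the scatter) and a number 4.02 log units lower from compound 2 to compound 4 (beyond the scatter) for the 2,6-dimethylphenyl and 4-fluoro-3,5-dimethylphenyl compounds, so the span at this one position is greater than the earlier compounds showed, and the entering group lowers the number even though it has more heavy atoms than the group it replaces. Nothing available here accounts for the size of these steps.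

The exchange alters the ring, the carbonyl and the hydrogen-bond donor at once, so their shares remain unseparated. A pyridin-4-yl group set directly on the amide-type nitrogen, or a (phenylcarbonyl)amino group, would help divide them.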